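Amino for Chloro on a Shared Core: One Change, Two Settings

The source may hold more compounds than are shown below. What is called first, only, known or untested is meant among the compounds shown, and "the series" means these compounds.

Measured compounds:
Compound 1, `Nc1nc(Cl)c2ncn(Cc3ccc(CCl)cc3)c2n1`: 19500 nM
Compound 2, `ClCc1cccc(Cn2cnc3c(Cl)nc(Cl)nc32)c1`: 2950 nM
Compound 3, `ClCc1ccc(Cn2cnc3c(Cl)nc(Cl)nc32)cc1`: 17800 nM

In a functional assay on DU-145 cells (Homo sapiens) for cytotoxicity, read by sulforhodamine B assay, with a stated time of 48 h (on this read-out lower numbers stand for stronger inhibition of growth and higher numbers for weaker inhibition of growth), compound 3 gives 17800 nM, and compound 1 gives 19500 nM. Compound 1 is made from compound 3 by one change: amino in place of chloro on an aromatic carbon. That change gave a 1.1-fold higher number from compound 3 to compound 1 (0.04 log units; within the scatter), so the two numbers stand together.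

Compound 2 gives 2950 nM in this assay, the lowest of the three numbers, and its gap to compound 3 and to compound 1 lies beyond the scatter. Compound 2 and compound 3 are built from the same atoms joined differently; the difference between the two cores is not broken down here.

Compound 4, `Nc1nc(Cl)c2ncn(Cc3cccc(CCl)c3)c2n1`, has not yet been measured. Among the compounds with values here, it is made from compound 2 by amino in place of chloro on an aromatic carbon, which is the same change as the one from compound 3 to compound 1, at the same place on the core. Because that earlier step gave a 1.1-fold higher number from compound 3 to compound 1 (0.04 log units; within the scatter), the step from compound 2 to compound 4 is expected to be a 1.1-fold higher number from compound 2 to compound 4 (0.05 log units; within the scatter), again within the scatter; this rests on a single earlier example, so the range is kept wide. For compound 4 the estimate in this assay is 3300 nM, between 1400 nM and 8000 nM.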

Compound 4, concentration for total growth inhibition: 16600 nM
Compound 4: the middle estimate sits 5.0-fold (0.70 log units) below what was measured, and the stated range ends below it.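

In this assay, putting amino in place of chloro on the core of compound 2 gave a 5.6-fold higher number from compound 2 to compound 4 (0.75 log units; beyond the scatter), so on this core the change moves the number well past what repeated measurements would scatter by, and the low value of compound 2 is lost. Set beside a 1.1-fold higher number from compound 3 to compound 1 (0.04 log units; within the scatter), this shows that the same change at the same place on the ring did not carry the same size of step from one core to the other: the same change on two cores in this assay, a 1.1-fold higher number (0.04 log units; within the scatter) from compound 3 to compound 1 and a 5.6-fold higher number (0.75 log units; beyond the scatter) from compound 2 to compound 4, 5.1-fold (0.71 log units) apart, beyond the scatter of two such steps. Within the data shown here, this shows that, in this series, a step seen on one core cannot simply be copied onto the other, but it rests on only two pairs of compounds, so it gives no general rule, and nothing here says why the two steps part ways.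

Still open, on these data alone, is whether a methylamino or a hydroxyl group in that same place would follow amino on either core. Also open, as far as these compounds go, is whether the two cores would stay this far apart if the chloromethyl group on the benzyl ring gave way to a plain methyl or a bromomethyl group.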